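Cytotoxicity notes on the halophenoxy chain series, compound 4

The source may hold more compounds than are shown below. What is called first, only, known or untested is meant among the compounds shown, and "the series" means these compounds.

Values in a functional assay on cells (Homo sapiens) for cytotoxicity; on this read-out higher numbers stand for lower toxicity in this test and lower numbers for higher toxicity in this test:
compound 1 `O=C1N(CCCCCCOc2ccc(Br)cc2)CCN1c1ccncc1` gives > 25000 nM, a limit of the assay and not a number.
compound 2 `O=C1N(CCCCCCOc2ccc(C(F)(F)F)cc2)CCN1c1ccncc1` gives > 25000 nM, also a limit of the assay.
compound 3 `O=C1N(CCCCCCCOc2ccc(Br)cc2)CCN1c1ccncc1` gives > 25000 nM, again a limit of the assay.

Compound 3 therefore stands where every measured member of the series stands: at the upper limit of this assay, with no number read for any of them, as the limit of > 25000 nM in this assay, at which 3 of the 3 values shown sit, records. The two measured steps, a step that the two limits leave unreadable from compound 1 to compound 2 and a step that the two limits leave unreadable from compound 1 to compound 3, are both unreadable because both ends sit at the limit, so no size and no direction can be taken from them.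

Compound 4 `O=C1N(CCCCCCOc2ccc(Cl)cc2)CCN1c1ccncc1` differs from compound 3 by 4-chlorophenoxy in place of (4-bromophenoxy)methyl on a saturated chain carbon, six bonds along the chain from an amide-type nitrogen in a ring. The exchange of bromo for chloro on the aromatic ring and the shortening of the chain by one carbon have no readable counterpart among the measured steps; nothing measured shows a step beyond the scatter in either direction, and nothing shows one within it either.

The expectation rests only on the three limits. Compound 4 is expected to give 40000 nM, with a range of 20000 nM to 120000 nM, most likely reported again as a limit. The expected step is a step that the limit leaves unreadable from compound 3 to compound 4, none beyond the scatter.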

Compound 4, half-maximal cytotoxic concentration: > 25000 nM
Compound 4: only a limit was reported (the forecaster's own chance of this, stated with the estimate: 85%); the middle value is on the limit's open side.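

No step can be read from compound 4 to compound 1, compound 2 or compound 3, because all four compounds sit at the same assay limit, which is a limit and not a number: the limit of > 25000 nM in this assay, at which 4 of the 4 values shown sit.

The compounds shown leave open whether chloro, bromo, trifluoromethyl or the (4-bromophenoxy)methyl exchange differ at all in this assay.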